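Ring Size and Saturation on the Aromatic Nitrogen

This account rests on a few compounds, and the source may have more. Where it says the series, first, only, none or still open, it means among the compounds named here.

Compound 1 `O=C(O)CC1=C(n2nc(-c3c(-c4ccccc4)nn4ccccc34)ccc2=O)CCCC1` gives 15 nM in an assay on cell membranes for inhibition of adenosine receptor A1 (Rattus norvegicus); a higher number here means a weaker inhibitor, a lower number a stronger inhibitor.
Compound 2 `O=C(O)C[C@@H]1CCCC[C@H]1n1nc(-c2c(-c3ccccc3)nn3ccccc23)ccc1=O` gives 3.6 nM in this assay.
Compound 3 `O=C(O)C[C@H]1CCCC[C@H]1n1nc(-c2c(-c3ccccc3)nn3ccccc23)ccc1=O` gives 34 nM in this assay.

Compound 2 stands lowest of the three numbers in this assay. Its nearest neighbour is compound 1: a 4.2-fold lower number from compound 1 to compound 2 (0.62 log units; beyond the scatter). Compound 3 lies furthest away: a 9.4-fold higher number from compound 2 to compound 3 (0.98 log units; beyond the scatter), a gap that rests on (the fact that compounds 2 and 3 differ only in the configuration as drawn). Between the other two there is also a clear step: a 2.3-fold higher number from compound 1 to compound 3 (0.36 log units; beyond the scatter).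

Compound 4 `O=C(O)CC1=C(n2nc(-c3c(-c4ccccc4)nn4ccccc34)ccc2=O)CCCCC1` has not yet been measured. It differs from compound 2 in one place: 2-(carboxymethyl)cyclohept-1-en-1-yl in place of 2-(carboxymethyl)cyclohexyl on an aromatic nitrogen. Two parts of this change can be read against the measured steps. Going from the saturated ring of compound 2 to the ring with 1 double bond outside aromatic rings in compound 1 raised the number, as the reverse of a 4.2-fold lower number from compound 1 to compound 2 (0.62 log units; beyond the scatter) shows. The growth from a six-membered to a seven-membered ring has no measured counterpart among these compounds, so its direction is unknown.

Taking the measured part as the guide, compound 4 is expected to give a higher number than compound 2, a step of about a 6.9-fold higher number from compound 2 to compound 4 (0.84 log units; beyond the scatter). The estimate for compound 4 is 25 nM, with a range from 7 nM to 90 nM.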

Compound 4, half-maximal inhibitory concentration: 16 nM
Estimate against measurement, compound 4: 1.6-fold (0.19 log units) above; low and high end bracket the measured number.
By their numbers in this assay, from the lowest: compound 2; then compounds 1 and 4 (each within the scatter of the next); then compound 3.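

Growing the unsaturated ring from six-membered to seven-membered, the one part of this change with no earlier counterpart, leaves no readable difference in this assay: a 1.1-fold higher number from compound 1 to compound 4 (0.03 log units; within the scatter). The step from the saturated ring to the seven-membered unsaturated ring, a 4.4-fold higher number from compound 2 to compound 4 (0.65 log units; beyond the scatter), therefore reads much like the earlier step between compound 1 and compound 2, so among these compounds the number at this position on the aromatic nitrogen follows the ring double bond and the configuration rather than the ring size. Compound 3 goes against any simple rule that saturation gives the lower number, as it lies on the other side of the unsaturated rings: a 2.1-fold lower number from compound 3 to compound 4 (0.33 log units; beyond the scatter).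

Nothing to hand explains why the ring size makes so little difference here. Still open, going by these compounds, is whether a saturated seven-membered ring would show the same split between its two configurations as compounds 2 and 3, and how a five-membered ring, a longer carboxyethyl chain or an amide in place of the carboxylic acid would read in this assay.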